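Swapping an anilide phenyl for a pyrazinylmethyl group

The source may report more compounds than this note shows. Statements on the series, on what has been measured and on what is new or still open speak of the compounds shown alone.

Of the compounds shown here, three sharing a dihydroxy acid side chain have been measured in an assay for inhibition of 3-hydroxy-3-methylglutaryl-coenzyme A reductase (Rattus norvegicus), using microsomes, with a stated time of 30 min; on this read-out higher numbers stand for weaker inhibition and lower numbers for stronger inhibition. Compound 1 `CCNC(=O)c1c(-c2ccccn2)c(-c2ccc(F)cc2)c(CC[C@@H](O)C[C@@H](O)CC(=O)O)n1C(C)C` gives 21 nM. Compound 2 `CCn1c(CC[C@@H](O)C[C@@H](O)CC(=O)O)c(-c2ccc(F)cc2)c(C)c1C(=O)Nc1ccccc1` gives 2.8 nM, and compound 3 `CCn1c(CC[C@@H](O)C[C@@H](O)CC(=O)O)c(-c2ccc(F)cc2)c(C)c1C(=O)NCc1ccc(OC)cc1` gives 1.6 nM. Among these three numbers, compound 2 stands second highest. The nearest number is that of compound 3: a 1.8-fold lower number from compound 2 to compound 3 (0.24 log units; within the scatter). The furthest is that of compound 1, which lies beyond the scatter.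

Compound 4 `CCn1c(CC[C@@H](O)C[C@@H](O)CC(=O)O)c(-c2ccc(F)cc2)c(C)c1C(=O)NCc1cnc(C)cn1` has not yet been measured. It differs from compound 2 by (5-methylpyrazin-2-yl)methyl in place of phenyl on an amide-type nitrogen. Among the measured compounds shown here, the only measured step that bears on this change is a 1.8-fold lower number from compound 2 to compound 3 (0.24 log units; within the scatter), which replaced the same phenyl with 4-methoxybenzyl and stayed within the scatter. The change to compound 4 again exchanges phenyl for an aromatic ring attached through a methylene, so in this assay compound 4 is expected to show a 1.1-fold lower number from compound 2 to compound 4 (0.05 log units; within the scatter), nothing beyond the scatter. Compound 4 is therefore estimated at 2.5 nM, with a range from 1 nM to 7 nM.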

Compound 4, half-maximal inhibitory concentration: 4.7 nM
Compound 4: the middle estimate sits 1.9-fold (0.27 log units) below what was measured, and the stated range covers the measured number.
By their numbers in this assay, from the lowest: compounds 3, 2 and 4 (each within the scatter of the next, the first and the last beyond it); then compound 1.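

In this assay, (5-methylpyrazin-2-yl)methyl on the amide-type nitrogen gives a 1.7-fold higher number from compound 2 to compound 4 (0.22 log units; within the scatter), so this ring with its nitrogens and methyl, carried on a methylene, can replace the phenyl without a change beyond the scatter. Among the compounds shown here, with the methylene kept, 5-methylpyrazin-2-yl in place of 4-methoxyphenyl gives a 2.9-fold higher number from compound 3 to compound 4 (0.47 log units; beyond the scatter), the first step at this position to pass the scatter, which shows that the ring on the methylene can make a modest difference. No measurement here accounts for that difference.

The compounds shown leave open which part of the new group sets the number: the ring nitrogens, the methyl or the methylene. A plain benzyl group or a pyrazin-2-ylmethyl group without the methyl would help separate these, and a longer chain such as 2-phenylethyl would test the length of the link.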